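The source may hold more compounds than are shown below. What is called first, only, known or untested is meant among the compounds shown, and "the series" means these compounds.

Among the measured compounds shown here, compound 2 `CC(C)S(=O)(=O)N1CCC(CN(C2Cc3cc(C#N)ccc3N(Cc3cncn3C)C2)S(=O)(=O)c2ccccn2)CC1` gives 0.1 10^-6 cm/s in an ADME assay on Caco-2 cells (Homo sapiens) for permeability, in the apical to basolateral direction (on this read-out higher numbers stand for higher permeability and lower numbers for lower permeability), the lowest of the three numbers known, with compound 1 `Cn1cncc1CN1CC(N(CC2CCN(C(=O)CC(F)(F)F)CC2)S(=O)(=O)c2ccccn2)Cc2cc(C#N)ccc21` at 0.5 10^-6 cm/s and compound 3 `Cn1cncc1CN1CC(N(CC2CCN(C(=O)OC(C)(C)C)CC2)S(=O)(=O)c2ccccn2)Cc2cc(C#N)ccc21` at 15.5 10^-6 cm/s. Compound 4 `Cc1noc(C)c1CN(C1Cc2cc(C#N)ccc2N(Cc2cncn2C)C1)S(=O)(=O)c1ccccn1` differs from compound 2 by 3,5-dimethyl-1,2-oxazol-4-yl in place of 1-(isopropylsulfonyl)piperidin-4-yl on a saturated chain carbon bound to a sulfonamide nitrogen. The known steps touch only the substituent on the piperidine nitrogen: a 5.0-fold lower number from compound 1 to compound 2 (0.70 log units; beyond the scatter) and a 160-fold higher number from compound 2 to compound 3 (2.19 log units; beyond the scatter), both beyond the scatter and both placing the isopropylsulfonyl variant lowest. None replaces the piperidine itself, so they bear on this change only loosely, but both point upward from compound 2 when that group is altered. A rise beyond the scatter is therefore expected for compound 4, estimated as 5 10^-6 cm/s with a range of 1 10^-6 cm/s to 25 10^-6 cm/s, a step of a 50-fold higher number from compound 2 to compound 4 (1.70 log units; beyond the scatter).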

Compound 4, apparent permeability: 8 10^-6 cm/s
Estimate against measurement, compound 4: 1.6-fold (0.20 log units) below; the measured number falls inside the stated range.
By their numbers in this assay, from the lowest: compound 2; then compound 1; then compounds 4 and 3 (each within the scatter of the next).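

In this assay, the change at the saturated chain carbon bound to a sulfonamide nitrogen gives an 80-fold higher number from compound 2 to compound 4 (1.90 log units; beyond the scatter), so this position moves the read-out as well as the amine nitrogen in a ring. The swap replaces a six-membered non-aromatic ring with a five-membered aromatic ring, with fewer heavy atoms and the same hydrogen-bond acceptor count. Nothing at hand explains the rise.

From the compounds shown here alone, whether it follows from the aromatic ring, its two methyl groups or the loss of the 1-(isopropylsulfonyl)piperidin-4-yl group stays open. A phenyl, an unsubstituted 1,2-oxazol-4-yl or a piperidin-4-yl with a free amine at this place would separate these.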